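The source may report more compounds than this note shows. Statements on the series, on what has been measured and on what is new or still open speak of the compounds shown alone.

In a functional assay on KYSE-410 cells (Homo sapiens) for antiproliferative activity, read by MTT assay, with a stated time of 72 h (on this read-out higher numbers stand for weaker inhibition and lower numbers for stronger inhibition), compound 1 `O=C(Nc1ccc(F)cc1F)c1cc(=O)[nH]c2cc(Br)ccc12` gives > 20000 nM, which is a limit and not a number. Compound 2 `CC(=O)c1ccc(-c2ccc3c(C(=O)Nc4cccc(F)c4)cc(=O)[nH]c3c2)cc1` gives > 20000 nM, also a limit. Going by the values given here, compound 3 `O=C(Nc1cccc(F)c1)c1cc(=O)[nH]c2cc(-c3cccc(F)c3)ccc12` gives 10900 nM, the only true number so far; the rest of the series sits at the limit of > 20000 nM in this assay, at which 2 of the 3 values shown sit. Compound 4 `O=C(Nc1cccc(F)c1)c1cc(=O)[nH]c2cc(-c3cccnc3F)ccc12` is not yet measured and carries 2-fluoropyridin-3-yl in place of 3-fluorophenyl on an aromatic carbon. Among the compounds with values here, the one measured step at this place is an at least 1.8-fold lower number from compound 2 to compound 3 (0.26 log units; that floor lies within the scatter), and one of its ends is a limit. No step beyond the scatter is therefore expected in this assay, in either direction. The expected step is a 1.1-fold higher number from compound 3 to compound 4 (0.04 log units; within the scatter). Compound 4 is estimated at 12000 nM, with a range of 5500 nM to 20000 nM.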

Compound 4, half-maximal inhibitory concentration: 11600 nM
Compound 4: the middle estimate sits 1.0-fold (0.01 log units) above what was measured, within the range that was stated.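

Replacing 3-fluorophenyl with 2-fluoropyridin-3-yl gives a 1.1-fold higher number from compound 3 to compound 4 (0.03 log units; within the scatter) in this assay, so a second aryl group at this position, now with a ring nitrogen, also gives a true number. Against 4-acetylphenyl the same group gives an at least 1.7-fold lower number from compound 2 to compound 4 (0.23 log units; that floor lies within the scatter). The value of compound 2 is a limit, so that step is only a floor.

Open, from the compounds shown here alone, is whether an amine or a carboxylic acid on this aromatic carbon would give a step beyond the scatter. Also open is the true size of any step that ends at a limit: the limit of > 20000 nM in this assay, at which 2 of the 4 values shown sit.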